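The compounds below may be only part of what the source reports. "The series", "measured", "known", "first", "only" and "open" are said of these compounds alone.

Measured compounds:
compound 1, `c1ccc(CC2CCN(CCCc3c[nH]c4ccc(-n5cnnc5)cc34)CC2)cc1`, 120 nM
compound 2, `CN(Cc1ccccc1)C1CCN(CCCc2c[nH]c3ccc(-n4cnnc4)cc23)CC1`, 1400 nM
compound 3, `FC1(Cc2ccccc2C(F)(F)F)CCN(CCCc2c[nH]c3ccc(-n4cnnc4)cc23)CC1`, 290 nM

All three were tested in a functional assay on CHO cells for agonist activity at 5-hydroxytryptamine receptor 1B (Homo sapiens), read by GTPgammaS binding; a higher number here means that more compound is needed for the effect, a lower number that less compound is needed. Among them compound 3 gives 290 nM, the second highest of the three numbers; compound 1 gives 120 nM, while compound 2 gives 1400 nM. Compound 4, `CC(CC1(F)CCN(CCCc2c[nH]c3ccc(-n4cnnc4)cc23)CC1)c1ccccc1`, has not yet been measured. It differs from compound 3 in one place: 1-phenylethyl in place of 2-(trifluoromethyl)phenyl on a saturated chain carbon bound to a saturated ring carbon. Within the data shown here, the only step measured so far, a 12-fold higher number from compound 1 to compound 2 (1.07 log units; beyond the scatter), concerns a different change on the saturated ring carbon and gives no direct guide. The two values of compound 1 and compound 3 show that the shared core tolerates a change in the group that hangs from the saturated ring carbon, with a step beyond the usual scatter but not a large one. Among the measured compounds shown here, no measured step tells how the exchange of the trifluoromethyl-bearing ring for the phenylethyl chain will play out. The step is therefore expected to be small: a 1.5-fold lower number from compound 3 to compound 4 (0.16 log units; within the scatter). The number for compound 4 in this assay is estimated at 200 nM, with a range from 70 nM to 600 nM.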

Compound 4, half-maximal effective concentration: 510 nM
Compound 4: the middle estimate sits 2.6-fold (0.41 log units) below what was measured, within the range that was stated.
By their numbers in this assay, from the lowest: compound 1; then compounds 3 and 4 (each within the scatter of the next); then compound 2.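

In this assay the exchange of 2-(trifluoromethyl)phenyl for 1-phenylethyl on a saturated chain carbon bound to a saturated ring carbon comes to a 1.8-fold higher number from compound 3 to compound 4 (0.25 log units; within the scatter) and leaves the two compounds indistinguishable. This first measured step at this position shows that, with a six-membered aromatic ring of carbon only present on both sides, a group of 8 carbon atoms can stand in for one of 7 carbon and 3 fluorine atoms without a step beyond the scatter. No supporting evidence is available to explain this outcome.

Both groups carry that aromatic ring, so the compounds shown leave open how a group without it, such as a plain methyl, would fare at this position. Also open, from the compounds shown here alone, is how a group carrying an amine or a carboxylic acid would read in this assay here.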